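Cyclohexyl for thiophen-3-yl on the fused core

The compounds below may be only part of what the source reports. "The series", "measured", "known", "first", "only" and "open" are said of these compounds alone.

In a functional assay on cells for antagonist activity at prostaglandin E2 receptor EP1 subtype (Rattus norvegicus), read by fluorescence and calcium flux, with a stated time of 60 s (on this read-out lower numbers stand for stronger inhibition and higher numbers for weaker inhibition), compound 2 `O=C(O)c1cccc(Cc2c(-c3ccsc3)nn3cc(Cl)ccc23)n1` gives 110 nM, and compound 1 `O=C(O)c1cccc(Cc2c(-c3ccccc3)nn3cc(C4CC4)ccc23)n1` gives 190 nM; the two values lie within the scatter of each other, so neither stands apart on this read-out. Compound 3 `O=C(O)c1cccc(Cc2c(C3CCCCC3)nn3cc(Cl)ccc23)n1` is not yet measured. It differs from compound 2 in one place: cyclohexyl in place of thiophen-3-yl on an aromatic carbon. Among the measured compounds shown here, no step between measured compounds covers this change, so the size is uncertain; a small step toward weaker inhibition, possibly no more than the scatter, is expected for compound 3, as a 2.3-fold higher number from compound 2 to compound 3 (0.36 log units; beyond the scatter). Compound 3 is therefore estimated at 250 nM, with a range from 80 nM to 800 nM.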

Compound 3, half-maximal inhibitory concentration: 1200 nM
Compound 3: middle estimate off by 4.8-fold (0.68 log units), on the low side; measured number outside the range, above it.
By their numbers in this assay, from the lowest: compounds 2 and 1 (each within the scatter of the next); then compound 3.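

Cyclohexyl in place of thiophen-3-yl, on the aromatic carbon next to the ring nitrogen, gives in this assay an 11-fold higher number from compound 2 to compound 3 (1.04 log units; beyond the scatter) with the rest of the molecule unchanged. Among the compounds shown here, compounds 1 and 2 differ in more than one place, so only this pair isolates the position, and here a non-aromatic ring of carbon only does not match the five-membered aromatic ring. No measurement at hand accounts for the step.

Going by these compounds, whether the aromatic ring or its sulfur matters stays open. A furan-3-yl or a cyclopentyl group at this carbon would help to separate the two.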